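This account rests on a few compounds, and the source may have more. Where it says the series, first, only, none or still open, it means among the compounds named here.

Measured so far in an assay on L cells for inhibition of Protein-serine O-palmitoleoyltransferase porcupine (Mus musculus), read by reporter gene assay, with a stated time of 24 h; a higher number here means that more compound is needed for the effect, a lower number that less compound is needed:
Compound 1 `O=C(CSc1nc2c(c(=O)n1-c1ccccc1)SCC2)Nc1ccc(-c2ccccn2)cc1`; compound 1 gives 4 nM
Compound 2 `CCOC(=O)c1ccc2nc(NC(=O)CNC(=O)c3nn(-c4ccccc4)c(=O)c4ccccc34)sc2c1`; compound 2 gives > 25000 nM
Compound 3 `COc1ccc2nc(NC(=O)CSc3nc4c(c(=O)n3-c3ccccc3)SCC4)sc2c1`; compound 3 gives 40 nM

Of the two numbers recorded in this assay, compound 1 holds the lower one. Compound 3, its nearest neighbour in value, sits at a higher number, and that gap lies beyond the usual scatter of repeated measurements. The value of compound 2 is a limit of the assay rather than a number: the limit of > 25000 nM in this assay, at which 1 of the 3 values shown sits.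

Compound 4 `O=C(CSc1nc2c(c(=O)n1-c1ccccc1)SCC2)Nc1ccc(N2CCCCC2)cc1` has not yet been measured. It differs from compound 1 in one place: piperidin-1-yl in place of pyridin-2-yl on an aromatic carbon. Among the compounds with values here, no pair of measured compounds mirrors this change, so there is no measured step to lean on; the expectation rests only on where compound 1 stands in this assay and on the nature of the change, an aromatic ring giving way to a non-aromatic one at the same position.

Compound 4 is expected to need more compound than compound 1 in this assay, a step of a 15-fold higher number from compound 1 to compound 4 (1.18 log units; beyond the scatter) that would reach beyond the scatter. The estimate for compound 4 in this assay is 60 nM, with a range from 10 nM to 400 nM.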

Compound 4, half-maximal effective concentration: 30 nM
Beside the measured number, compound 4's estimate is 2.0-fold (0.30 log units) above it, and the stated range covers the measured number.
By their numbers in this assay, from the lowest: compound 1; then compounds 4 and 3 (each within the scatter of the next). At a limit, above all of these: compound 2.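

The step of a 7.5-fold higher number from compound 1 to compound 4 (0.88 log units; beyond the scatter) in this assay is the only change at a single place among the compounds shown, and it gives the first direct reading of the position on an aromatic carbon, para to a large group. The two groups match in what can be counted, each being one six-membered ring with one hetero atom and no net charge, so the aromatic pyridin-2-yl and the non-aromatic piperidin-1-yl differ here chiefly in the ring type, and with the non-aromatic ring compound 4 still gives a measured number, 30 nM, rather than a limit. The step is beyond the scatter but modest, and nothing measured here accounts for its size.

The compounds shown leave open how a phenyl ring, a morpholin-4-yl ring or an open-chain amine such as dimethylamino would stand at this same place, and so whether the ring type or the ring nitrogen matters more. They also leave open whether the same exchange would give a step of similar size on another core.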